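The source may hold more compounds than are shown below. What is called first, only, known or untested is meant among the compounds shown, and "the series" means these compounds.

The shared core of compound 1 `Cc1cc(-c2ccc(C=O)cc2)cn2c(CSCCc3ccccc3)cnc12` carries a 4-formylphenyl on an aromatic carbon; compound 2 `Cc1cc(-c2ccco2)cn2c(CSCCc3ccccc3)cnc12` carries a furan-2-yl there and compound 3 `Cc1cc(-n2cccc2)cn2c(CSCCc3ccccc3)cnc12` a 1H-pyrrol-1-yl. In an ADME assay on HEL cells (Homo sapiens) for cytotoxicity, with a stated time of 3 days (a lower number here means that less compound is tolerated, a higher number that more compound is tolerated), compound 1 gives 100 ug/mL. For compound 2 this assay reports only a limit, > 4 ug/mL. For compound 3 this assay likewise reports only a limit, >= 4 ug/mL. Compound 3 thus stands at a limit of this assay (the limit of >= 4 ug/mL in this assay, at which 1 of the 3 values shown sits), and of the two other values shown one is a number and one is itself a limit (the limit of > 4 ug/mL in this assay, at which 1 of the 3 values shown sits). The measured steps reaching compound 3 are a step that the limit leaves unreadable from compound 1 to compound 3 and a step that the two limits leave unreadable from compound 2 to compound 3; neither can be sized. Compound 4 `Cc1cc(C#N)cn2c(CSCCc3ccccc3)cnc12` differs from compound 3 in one place: cyano in place of 1H-pyrrol-1-yl on an aromatic carbon. No measured step covers a cyano on this carbon, and the two steps leading to compound 3 yield no readable size, so the data give no ground for expecting a step in this assay in either direction beyond the scatter; the one number shown, that of compound 1, is the only anchor. Compound 4 is accordingly expected to give 20 ug/mL, between 4 ug/mL and 100 ug/mL. This estimate means an expected step that the limit leaves unreadable from compound 3 to compound 4.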

Compound 4, minimum cytotoxic concentration: 20 ug/mL
For compound 4 middle estimate and measured number coincide at the digits printed, and the stated range covers the measured number.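

In this assay, among these compounds, the cyano group gives the first step at this aromatic carbon that can be sized, and it shows that replacing 4-formylphenyl here moves the number beyond the scatter: a 5.0-fold lower number from compound 1 to compound 4 (0.70 log units; beyond the scatter). The step from compound 2 to compound 4 cannot be read, so cyano and furan-2-yl cannot be ranked on this carbon, because compound 2 gives only a limit: the limit of > 4 ug/mL in this assay, at which 1 of the 4 values shown sits. The step from compound 3 to compound 4 cannot be read either, so the exchange of 1H-pyrrol-1-yl for cyano has no measurable size, because compound 3 also gives only a limit: the limit of >= 4 ug/mL in this assay, at which 1 of the 4 values shown sits.

Among the compounds shown here, what remains open is how far the number would move with another group on this carbon, such as an amine or a carboxylic acid, since a single readable step marks out only one change at this position. As far as these compounds go, it is also open whether cyano in place of 4-formylphenyl would give a step of like size if the chain on the shared core were longer.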